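A few compounds are considered here, and "the series" means these few. Any claim that something is new, unique, unknown or untested is made for them only; others in the source may bear on it.

Compound 1 `CC(C)=CCC/C(C)=C/CC1Cc2c(OCCCNC(=O)c3ccc([N+](=O)[O-])cc3)cc(=O)n(CCCO)c2CC1(C)C` gives 16.8%
Compound 2 `COc1ccc(OCCCOc2cc(=O)n(CCCO)c3c2CC(C/C=C(\C)CCC=C(C)C)C(C)(C)C3)cc1` gives 20%

In a functional assay on PANC-1 cells (Homo sapiens) for inhibition, read by MTT assay, with a stated time of 24 h, tested at 10 uM (on this read-out lower numbers stand for less inhibition and higher numbers for more inhibition at the one concentration tested (going by the name of the read-out)), compound 2 stands highest of the two numbers, yet the step of a number 3.2 percentage points higher from compound 1 to compound 2 (within the scatter) is within the scatter. Compound 3 `CC(C)=CCC/C(C)=C/CC1Cc2c(OC(=O)Nc3ccc(Cl)c(Cl)c3)cc(=O)n(CCCO)c2CC1(C)C` differs from compound 2 by (3,4-dichlorophenyl)carbamoyl in place of 3-(4-methoxyphenoxy)propyl on an oxygen on an aromatic ring. For the measured compounds named here, no measured step bears on this change; the single step from compound 1 to compound 2 altered only the group on the chain, and it was small. No step beyond the scatter is therefore expected, though the range is wide. Compound 3 is expected to give 19%, between 5% and 40%. The estimated step is a number 1 percentage points lower from compound 2 to compound 3 (within the scatter).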

Compound 3, a percentage reported as inhibition, at one concentration (the size of the read-out at that concentration, not a potency): 20%
The estimate for compound 3 lay 1 percentage points below the measured number; the range from low to high includes it.
By their numbers in this assay, from the lowest: compounds 1, 2 and 3 (each within the scatter of the next).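

In this assay, replacing 3-(4-methoxyphenoxy)propyl with (3,4-dichlorophenyl)carbamoyl on an oxygen on an aromatic ring gives no change at the digits printed from compound 2 to compound 3 (within the scatter). Where the earlier step altered only the end of the chain, this one exchanges the whole group on that oxygen, and the read-out still stays within the scatter. Nothing available explains this result.

As far as these compounds go, whether any group at this oxygen can move the read-out beyond the scatter remains open. A simple amine or a carboxylic acid on a propyl chain there would test this.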